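Swapping the amine on a dithiocarbamate chromone pair

This account rests on a few compounds, and the source may have more. Where it says the series, first, only, none or still open, it means among the compounds named here.

Measured compounds:
compound 1, `CC(C)N(C(=S)SCc1oc2ccccc2c(=O)c1Cl)C(C)C`, 18100 nM
compound 2, `Cc1ccc2c(=O)c(CSC(=S)N3CCCC3)coc2c1`, 5900 nM
compound 3, `O=c1c(Cl)c(CSC(=S)N2CCCC2)oc2ccccc12`, 1400 nM

All three numbers come from a functional assay on SW480 cells (Homo sapiens) for antiproliferative activity, read by MTT assay, with a stated time of 72 h; a higher number here means a weaker inhibitor, a lower number a stronger inhibitor. Within this set, compound 3 gives the lowest number, and compound 1 the highest; compound 2 stands between them, with its steps to both beyond the scatter. The pair compound 3 and compound 1 differ in one place only: diisopropylamino in place of pyrrolidin-1-yl on a thiocarbonyl carbon. That exchange made a 13-fold higher number from compound 3 to compound 1 (1.11 log units; beyond the scatter).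

Compound 4, `Cc1ccc2c(=O)c(CSC(=S)N(C(C)C)C(C)C)coc2c1`, has not yet been measured in this assay. It is related to compound 2 by the same change: diisopropylamino in place of pyrrolidin-1-yl on a thiocarbonyl carbon, made at a place described in the same words as for the earlier pair. The difference between the core of compound 2 and the core of compound 3 is not broken down here.

Among the compounds with values here, because the one measured instance of this change is a 13-fold higher number from compound 3 to compound 1 (1.11 log units; beyond the scatter), a step of similar direction is expected from compound 2 to compound 4, but on a different core it is estimated more cautiously as an 8.5-fold higher number from compound 2 to compound 4 (0.93 log units; beyond the scatter). For compound 4 the estimated value is 50000 nM, expected to lie between 15000 nM and 160000 nM.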

Compound 4, half-maximal inhibitory concentration: > 25000 nM
Compound 4: only a limit was reported; the forecaster's own chance of this, stated with the estimate: 20%; the middle value lies beyond the limit too.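

In this assay, putting diisopropylamino in place of pyrrolidin-1-yl on a thiocarbonyl carbon gave an at least 4.2-fold higher number from compound 2 to compound 4 (0.62 log units; beyond the scatter), so on this second core the change again went with a higher number, that is, a weaker inhibitor. Compound 4 gives > 25000 nM, which is a limit of the assay and not a number. The direction of the change therefore carried from one core to the other in these two pairs, but the limit does not show whether its size carried over as well: the same change on two cores in this assay, a 13-fold higher number (1.11 log units; beyond the scatter) from compound 3 to compound 1 and an at least 4.2-fold higher number (0.62 log units; beyond the scatter) from compound 2 to compound 4; the limit leaves it open whether they differ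

The compounds shown leave open how other amines would behave on the thiocarbonyl carbon, for example a piperidine, a morpholine or a small open-chain amine such as dimethylamine, and whether pyrrolidin-1-yl is preferred over these as well as over diisopropylamino. They also leave open which part of the difference between the core of compound 2 and the core of compound 3 goes with the gap between their values, and how the change would behave on any further core.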